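The source may report more compounds than this note shows. Statements on the series, on what has been measured and on what is new or still open speak of the compounds shown alone.

Compound 3 `Fc1ccc(COc2nc3ccccc3s2)cc1` has been measured in a functional assay on the whole organism with Mus musculus as the target, in the writhing test, at a dose of 100 mg/kg by the intraperitoneal route; a higher number here means more inhibition at the dose given (going by the name of the read-out), a lower number less inhibition. In this assay compound 3 gives 51.9%. It stands level with compound 1 `c1ccc(COc2nc3ccccc3s2)cc1`, which in this assay gives 51.9%; the step of no change at the digits printed from compound 1 to compound 3 (within the scatter) lies within the scatter. A third measured analogue, compound 2 `Cc1ccc(COc2nc3ccccc3s2)cc1`, is reported in this assay as "not active" (no number reported), with no number given.

Compound 4 `N#Cc1ccc(COc2nc3ccccc3s2)cc1` has not yet been measured; it differs from compound 3 by cyano in place of fluoro on an aromatic carbon. Among the compounds with values here, the only measured step that resembles this change is no change at the digits printed from compound 1 to compound 3 (within the scatter), which showed that a fluoro group in that position made no difference beyond the scatter. Within the data shown here, no measured step involves a cyano group, and compound 2 is reported in this assay as "not active" (no number reported) without a number, so the outcome is uncertain on the low side. Because the step of no change at the digits printed from compound 1 to compound 3 (within the scatter) was flat, compound 4 is expected to lie somewhat below compound 3 rather than far from it. The estimate for compound 4 is 40%, within a range from 10% to 60%, and the expected step is a number 11.9 percentage points lower from compound 3 to compound 4 (beyond the scatter).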

Compound 4, a percentage reported as inhibition, in the whole organism at one dose (the size of the read-out at that dose, not a potency): "not active" (no number reported)
Compound 4: no number reported, and the estimate cannot be compared.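

Compound 4 carries no number in this assay, so no step from compound 3 to compound 4 can be read, and no measurement shown bears on this result. The compounds shown leave open how compound 4 would compare numerically with compound 3.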